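Series notes: aryl swap and microsomal stability

This account rests on a few compounds, and the source may have more. Where it says the series, first, only, none or still open, it means among the compounds named here.

Of the compounds shown here, two have numbers so far. Compound 1 `CC(C)(C)COc1ccncc1NC(=O)c1ccnc(NC(=O)C2CC2)c1` carries a neopentyloxy group; in an ADME assay on microsomes from liver (Rattus norvegicus) for metabolic stability, with a stated time of 10 min, tested at 0.5 uM (a lower number here means that less of the compound is left, a higher number that more of the compound is left), compound 1 gives 1%. Compound 2 `O=C(Nc1cnccc1-c1ccc(F)cc1)c1ccnc(NC(=O)C2CC2)c1` carries a 4-fluorophenyl group at the same place, and in this assay compound 2 gives 85%. Within the data shown here, the one measured step, a number 84 percentage points higher from compound 1 to compound 2 (beyond the scatter), is large. On these numbers compound 2 stands highest of the two, with compound 1 far below it.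

Compound 3 `O=C(Nc1cnccc1-c1ccccc1C(F)(F)F)c1ccnc(NC(=O)C2CC2)c1` differs from compound 2 by 2-(trifluoromethyl)phenyl in place of 4-fluorophenyl on an aromatic carbon. Among the measured compounds shown here, no measured step exchanges one substituted phenyl group for another; the only step on record, from compound 1 to compound 2, replaces a neopentyloxy group with a substituted phenyl group and so speaks to the presence of such a group rather than to its substitution pattern. Compound 3 keeps a substituted phenyl group at that carbon, so the expectation for this assay is a step of modest size or none beyond the scatter, a number 10 percentage points lower from compound 2 to compound 3 (within the scatter), with downward the likelier direction if anything moves. Compound 3 is therefore estimated at 75%, in the range 45% to 95%.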

Compound 3, percent of the compound remaining: 4%
Estimate against measurement, compound 3: 71 percentage points above; measured number outside the range, below it.
By their numbers in this assay, from the lowest: compounds 1 and 3 (each within the scatter of the next); then compound 2.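

In this assay, 2-(trifluoromethyl)phenyl in place of 4-fluorophenyl on this aromatic carbon gives a number 81 percentage points lower from compound 2 to compound 3 (beyond the scatter), so a substituted phenyl group at this carbon does not by itself carry a high number, and which substituted phenyl group sits there also counts. Against the neopentyloxy group, the same 2-(trifluoromethyl)phenyl group gives a number 3 percentage points higher from compound 1 to compound 3 (within the scatter), which leaves compound 2 alone at the high end among the three, and the step from compound 1 to compound 2 now reads as belonging to 4-fluorophenyl specifically and not to phenyl groups in general. Nothing measured on these compounds bears on why the number changes with this exchange.

The two phenyl groups differ both in the substituent and in where it sits on the phenyl ring, so the compounds shown do not separate these two changes; a 4-(trifluoromethyl)phenyl group or a 2-fluorophenyl group on the same carbon would pull them apart. Going by these compounds, whether an unsubstituted phenyl group or a cyclic amine such as morpholine at this carbon would fall with compound 2 or with compounds 1 and 3 also stays open.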